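Trading a Methoxypropoxy Chain for a Cyclohexyl Ring

The compounds below may be only part of what the source reports. "The series", "measured", "known", "first", "only" and "open" are said of these compounds alone.

Among the three measured compounds, compound 3 `COCCCOc1nc(C(C)(C)C)ccc1CNC(=O)C(C)c1ccc(NS(C)(=O)=O)c(F)c1` stands weakest: in an assay on cells for antagonist activity at transient receptor potential cation channel subfamily V member 1 (Homo sapiens), read by FLIPR and calcium flux, with a stated time of 6 min (on this read-out lower numbers stand for stronger inhibition and higher numbers for weaker inhibition), compound 3 gives 5.6 nM, whereas compound 1 `CCCCOc1nc(C(C)(C)C)ccc1CNC(=O)C(C)c1ccc(NS(C)(=O)=O)c(F)c1` gives 0.9 nM and compound 2 `CC(C(=O)NCc1ccc(C(C)(C)C)nc1OC1CCCC1)c1ccc(NS(C)(=O)=O)c(F)c1` gives 1.5 nM. Compound 4 `CC(C(=O)NCc1ccc(C(C)(C)C)nc1C1CCCCC1)c1ccc(NS(C)(=O)=O)c(F)c1` differs from compound 3 in one place: cyclohexyl in place of 3-methoxypropoxy on an aromatic carbon. Going by the values given here, two measured steps bear on this change. The step of a 6.2-fold higher number from compound 1 to compound 3 (0.79 log units; beyond the scatter) shows that bringing in the methoxy went with weaker inhibition, and the step of a 3.7-fold higher number from compound 2 to compound 3 (0.57 log units; beyond the scatter) shows that exchanging a carbon ring for the methoxypropyl chain did the same. Among the compounds with values here, removing the methoxy and restoring a carbon ring should undo this, although no measured step removes the oxygen linker itself. Compound 4 is therefore expected to give 2 nM (range 0.6 nM to 8 nM), a step of a 2.8-fold lower number from compound 3 to compound 4 (0.45 log units; beyond the scatter).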

Compound 4, inhibition constant: 3.1 nM
The estimate for compound 4 lay 1.6-fold (0.19 log units) below the measured number; the range from low to high includes it.
By their numbers in this assay, from the lowest: compounds 1 and 2 (each within the scatter of the next); then compounds 4 and 3 (each within the scatter of the next).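

At this aromatic carbon next to the ring nitrogen, cyclohexyl, with no hydrogen-bond acceptors, can replace 3-methoxypropoxy, which has two, with a step of a 1.8-fold lower number from compound 3 to compound 4 (0.26 log units; within the scatter). Against the other oxygen-linked groups it does modestly worse: a 2.1-fold higher number from compound 2 to compound 4 (0.32 log units; beyond the scatter) when it replaces cyclopentyloxy, and a 3.4-fold higher number from compound 1 to compound 4 (0.54 log units; beyond the scatter) when it replaces butoxy. A directly attached ring therefore gives a higher number than these two groups, but compound 3 goes against that pattern. How an amine linker or a directly attached cyclopentyl ring would behave here remains open, and nothing available explains these differences.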